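The compounds below may be only part of what the source reports. "The series", "measured", "known", "first", "only" and "open" are said of these compounds alone.

The study measured two compounds in a functional assay for agonist activity at growth hormone secretagogue receptor type 1 (Homo sapiens), read by FLIPR (on this read-out lower numbers stand for smaller maximal responses and higher numbers for larger maximal responses), and leaves a third to be estimated. Compound 1 `C[C@@H]1CN(c2cccc(NS(=O)(=O)c3ccc(-c4ccccn4)s3)c2)C[C@H](C)N1` gives 0.8 in this assay. Compound 2 `COc1ccc(N2C[C@@H](C)N[C@@H](C)C2)cc1NS(=O)(=O)c1ccc(-c2ccccc2)cc1` gives 1 in this assay, the higher of the two numbers, and the gap to compound 1 is beyond the usual scatter of repeated measurements. Going by the values given here, no single-point step connects these two measured compounds, so their values stand side by side without a counted difference.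

Compound 3 `COc1ccc(N2C[C@@H](C)N[C@@H](C)C2)cc1NS(=O)(=O)c1ccc(-c2cccs2)cc1` is the unmeasured partner of compound 2, differing from it in one place: thiophen-2-yl in place of phenyl on an aromatic carbon. Only the phenyl is exchanged for thiophen-2-yl; the shared core and the rest of the molecule are unchanged.

Because compound 2 reaches 1 in this assay, the largest response on hand, the step from compound 2 to compound 3 is expected to be small, a number 0.10 lower from compound 2 to compound 3 (within the scatter), within the scatter or barely beyond it. Compound 3 is therefore estimated at 0.9, with a range from 0.7 to 1 in this assay.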

Compound 3, intrinsic activity: the largest response reached, as a fraction of the reference agonist's: 1
For compound 3 the middle estimate is 0.10 below the measured one, and the stated range covers the measured number.
By their numbers in this assay, from the lowest: compound 1; then compounds 2 and 3 (each within the scatter of the next).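

In this assay, thiophen-2-yl in place of phenyl, on an aromatic carbon para to a large group, gives no change at the digits printed from compound 2 to compound 3 (within the scatter). Going by these compounds alone, at this position, a five-membered aromatic ring with one sulfur atom can therefore stand in for a six-membered aromatic ring of carbon only, with the maximal response staying within the scatter; the earlier compounds, joined by no single-point step, could not show this. The compounds shown offer no measurement that would explain this outcome.

They leave open whether a group of another kind at this place, such as an amine or a carboxylic acid, would keep the maximal response. They also leave open whether the same exchange would give a similar result on a different core, or how it would affect anything other than the maximal response.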